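Methyl for Fluoro: Expecting Compound 3 from Compound 1

The source may report more compounds than this note shows. Statements on the series, on what has been measured and on what is new or still open speak of the compounds shown alone.

Among the compounds with values here, in an assay on isolated protein for inhibition of protein deacetylase HDAC6 (Homo sapiens) (on this read-out lower numbers stand for stronger inhibition and higher numbers for weaker inhibition), compound 1 `O=C(NO)c1ccc(Cn2ccc3cc(C(=O)c4ccc(F)cc4)ccc32)cc1` gives 9.25 nM, the lowest of the two numbers measured so far. Within the data shown here, the only other measured compound, compound 2 `COc1cc(C(=O)c2ccc3c(ccn3S(=O)(=O)c3cccc(/C=C/C(=O)NO)c3)c2)cc(OC)c1OC`, gives 562 nM in this assay, a far higher number that lies well beyond the usual scatter; since compound 2 differs from compound 1 in many places at once, its value shows only the spread of the series and nothing about a single change.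

Compound 3 `Cc1ccc(C(=O)c2ccc3c(ccn3Cc3ccc(C(=O)NO)cc3)c2)cc1` is compound 1 altered in one place: methyl in place of fluoro on an aromatic carbon, para to a large group, so that the (4-fluorophenyl)carbonyl becomes a (4-methylphenyl)carbonyl. Among the measured compounds shown here, no measured pair isolates this swap, so the step has to be judged from the nature of the change alone. Both groups are a single heavy atom with no donors or acceptors, and the hydroxamic portion that the two compounds share is untouched.

Compound 3 is therefore expected to land close to compound 1, with an estimated step from compound 1 to compound 3 of a 1.3-fold higher number from compound 1 to compound 3 (0.11 log units; within the scatter), not beyond the scatter. The estimate for compound 3 in this assay is 12 nM, with a range from 4 nM to 36 nM.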

Compound 3, half-maximal inhibitory concentration: 11.9 nM
For compound 3 the middle estimate is 1.0-fold (0.00 log units) above the measured one, and the stated range covers the measured number.
By their numbers in this assay, from the lowest: compounds 1 and 3 (each within the scatter of the next); then compound 2.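

In this assay, within the data shown here, the swap of fluoro for methyl on an aromatic carbon, para to a large group, amounts to a 1.3-fold higher number from compound 1 to compound 3 (0.11 log units; within the scatter) and is the first single change in this account that can be read on its own, since compound 2 differs from compound 1 in many places at once. It shows that, on the core of compound 1 and with the hydroxamic portion unchanged, 4-fluorophenyl and 4-methylphenyl cannot be told apart on this read-out, so fluoro is not needed at this position to keep the number where compound 1 has it. No measurement at hand bears on why these two groups read alike.

Going by these compounds, the two compounds span only a pair of single-atom groups, so it remains open whether the position would accept something of a different kind, such as an amine, a carboxylic acid or a longer chain like butyl. On these data alone, it also remains open whether the same swap would read alike on the core of compound 2.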